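A ring for a chain on the amine of compound 3

The source may report more compounds than this note shows. Statements on the series, on what has been measured and on what is new or still open speak of the compounds shown alone.

Compound 1 `NS(=O)(=O)Oc1ccc2c(c1)CN(C(=O)c1ccc(N3CCC(N4CCCCC4)CC3)cc1)CC2` gives 53.7% in an assay on HEK293 cells for inhibition of Steryl-sulfatase (Homo sapiens), tested at 1 uM; a higher number here means a stronger effect of the compound at the concentration tested, a lower number a weaker effect. Compound 2 `CCN(Cc1ccc(F)cc1)c1cccc(C(=O)N2CCc3ccc(OS(N)(=O)=O)cc3C2)c1` gives 66.5%, and compound 3 `CN(CCCN1CCCCC1)c1cccc(C(=O)N2CCc3ccc(OS(N)(=O)=O)cc3C2)c1` gives 30.6%. Compound 3 is the lowest of the three: the nearest number is compound 1, the furthest is compound 2, and the drop a number 35.9 percentage points lower from compound 2 to compound 3 (beyond the scatter) is large. Compound 4 `NS(=O)(=O)Oc1ccc2c(c1)CN(C(=O)c1cccc(N3CCc4ccccc4C3)c1)CC2` is not yet measured. It differs from compound 3 in one place: 1,2,3,4-tetrahydroisoquinolin-2-yl in place of methyl(3-(piperidin-1-yl)propyl)amino on an aromatic carbon.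

Within the data shown here, only the step from compound 2 to compound 3 touches the same position, and it shows that the entering group there moves the read-out by a large amount. The tetrahydroisoquinolinyl group of compound 4 brings an aromatic ring into the amine substituent, as the fluorobenzyl of compound 2 does, while the piperidinylpropyl chain of compound 3 leaves. An upward step a number 24.4 percentage points higher from compound 3 to compound 4 (beyond the scatter) is therefore expected, roughly back toward the level of compound 1 or compound 2. Compound 4 is estimated at 55%, with a range from 35% to 75%.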

Compound 4, a percentage reported as inhibition, at one concentration (the size of the read-out at that concentration, not a potency): 50.2%
Estimate against measurement, compound 4: 4.8 percentage points above, and the stated range covers the measured number.
By their numbers in this assay, from the lowest: compound 3; then compounds 4 and 1 (each within the scatter of the next); then compound 2.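

In this assay, the step of a number 19.6 percentage points higher from compound 3 to compound 4 (beyond the scatter) shows that a large part of the loss seen with the methyl(3-(piperidin-1-yl)propyl)amino group is recovered at this aromatic carbon when the 1,2,3,4-tetrahydroisoquinolin-2-yl group enters. The recovery is only partial: the step of a number 16.3 percentage points lower from compound 2 to compound 4 (beyond the scatter) leaves compound 4 short of the open ethyl(4-fluorobenzyl)amino group, so all three amine substituents at this position now stand apart from one another. No measurement here explains these differences.

As far as these compounds go, whether the fluorine of compound 2 contributes to its higher number remains open, and an unsubstituted benzylamino group at the same carbon would address that. From the compounds shown here alone, it is also open how a morpholine ring in this position would compare with the 1,2,3,4-tetrahydroisoquinolin-2-yl group.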